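Removing a Ring Methyl on a Bridged Amine Core

The source may report more compounds than this note shows. Statements on the series, on what has been measured and on what is new or still open speak of the compounds shown alone.

Compound 1 `Clc1ccncc1C1=CC2CNCC(C1)C2` gives 3 nM in an in vitro assay on SH-EP1 cells for displacement of a labelled ligand from Neuronal acetylcholine receptor; alpha4/beta2 (Homo sapiens); a lower number here means a stronger inhibitor, a higher number a weaker inhibitor.
Compound 2 `CN1CC2C=C(c3cnccc3Cl)CC(C2)C1` gives 1160 nM in this assay.
Compound 3 `CN1C[C@H]2C=C(c3cccnc3)C[C@H](C2)C1` gives 2.1 nM in this assay.

Compounds 2 and 1 share a core and differ in one place: hydrogen in place of methyl on an amine nitrogen in a ring. This single change brought a 390-fold lower number from compound 2 to compound 1 (2.59 log units; beyond the scatter), a step far beyond the usual scatter, so for this pair the unsubstituted amine nitrogen goes with the much lower number.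

Compound 3 carries a different core from compound 2; the difference between the two cores is not broken down here, and their values simply show a wide gap in this assay. Compound 3 and compound 1 lie within the scatter of each other, so nothing separates them.

Compound 4 `C1=C(c2cccnc2)C[C@H]2CNC[C@@H]1C2` has not yet been measured. It relates to compound 3 exactly as compound 1 relates to compound 2: hydrogen in place of methyl on an amine nitrogen in a ring. The place of the change is the same in both pairs, so this is the same change made on a second core.

Within the data shown here, the only guide for compound 4 is the earlier step, and compound 3 already gives a low number, 2.1 nM. Compound 4 is therefore expected to give a lower number than compound 3, with an estimated step of a 7.0-fold lower number from compound 3 to compound 4 (0.85 log units; beyond the scatter). The estimate for compound 4 in this assay is 0.3 nM, with a likely range from 0.05 nM to 1.5 nM.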

Compound 4, inhibition constant: 0.2 nM
For compound 4 the middle estimate is 1.5-fold (0.18 log units) above the measured one, within the range that was stated.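

Putting hydrogen in place of methyl on the amine nitrogen in the ring gives an 11-fold lower number from compound 3 to compound 4 (1.02 log units; beyond the scatter) in this assay, so the direction of the step seen on the core of compound 2 also holds on the core of compound 3, even though compound 3 already sits at a low number. The direction carries over from one core to the other, but the size of the step does not: the same change on two cores in this assay, a 390-fold lower number (2.59 log units; beyond the scatter) from compound 2 to compound 1 and an 11-fold lower number (1.02 log units; beyond the scatter) from compound 3 to compound 4, 37-fold (1.57 log units) apart, beyond the scatter of two such steps. These two pairs show that the change can be worthwhile on both cores, yet they do not show which difference between the cores goes with the larger step, and they give no firm size to expect on a third core.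

The compounds shown leave open how the same amine nitrogen would behave with something other than hydrogen or methyl on it, such as an ethyl group, a longer chain or an acyl group that turns the amine into an amide. They also leave open whether the lower numbers of the hydrogen-bearing compounds would hold in any test other than this assay.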